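Dropping the anilino group from an amide nitrogen

The source may hold more compounds than are shown below. What is called first, only, known or untested is meant among the compounds shown, and "the series" means these compounds.

Of the compounds shown here, three sharing one core have been tested so far. Compound 1 `Nc1sc2c(c1C(=O)O)CCN(Cc1ccccc1)C2` gives 8000 nM in an in vitro assay on CHOk1 cells with adenosine receptor A1 (Homo sapiens) as the target; on this read-out lower numbers stand for an effect already at smaller amounts and higher numbers for an effect only at larger amounts of compound. Compound 2 `NNC(=O)c1c(N)sc2c1CCN(Cc1ccccc1)C2` gives 8900 nM in this assay, and compound 3 `Nc1sc2c(c1C(=O)NNc1ccccc1)CCN(Cc1ccccc1)C2` gives 7800 nM. All three numbers sit within the usual scatter of one another, so no ranking among them can be drawn; compound 3 stands on a level shared with compound 1 and compound 2.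

The next compound is compound 4 `NC(=O)c1c(N)sc2c1CCN(Cc1ccccc1)C2`. Its difference from compound 3 is hydrogen in place of anilino on an amide-type nitrogen.

Two of the measured steps speak to this change. The step of a 1.1-fold lower number from compound 2 to compound 3 (0.06 log units; within the scatter) added a phenyl to the amine nitrogen that is now stripped back, and the step of a 1.0-fold lower number from compound 1 to compound 3 (0.01 log units; within the scatter) built the anilinoamino group up from a hydroxy group in the first place. Both moved the number by less than the scatter. Since the change from compound 3 to compound 4 undoes part of what those steps built, no step beyond the scatter is expected in this assay, in either direction.

For compound 4 a value of 8000 nM is therefore expected, within a range of 4000 nM to 16000 nM, which corresponds to an expected step of a 1.0-fold higher number from compound 3 to compound 4 (0.01 log units; within the scatter).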

Compound 4, half-maximal effective concentration: > 20000 nM
Compound 4: a limit, no number; the forecaster's own chance of this, stated with the estimate: 10%; at least 2.5-fold (0.39 log units) between middle value and limit.
By their numbers in this assay, from the lowest: compounds 3, 1 and 2 (each within the scatter of the next). At a limit, above all of these: compound 4.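

For compound 4 the reading in this assay is a limit of the assay and not a number: the limit of > 20000 nM in this assay, at which 1 of the 4 values shown sits.

Until now, every change on this carbonyl carbon and its amine nitrogen stayed within the scatter, which made the position look indifferent to what sits there. The plain amide breaks that picture, with an at least 2.5-fold higher number from compound 3 to compound 4 (0.40 log units; beyond the scatter), alongside an at least 2.2-fold higher number from compound 2 to compound 4 (0.35 log units; beyond the scatter) and an at least 2.5-fold higher number from compound 1 to compound 4 (0.39 log units; beyond the scatter). Hydroxy, aminoamino and anilinoamino share one level and amino alone stands apart, so the position does respond to change, but no simple trend with the length of the group fits, and compound 1, which carries only hydroxy there, goes against one.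

On these data alone, because compound 4 gives only a limit, how far it lies from the other three stays unknown. As far as these compounds go, whether a methyl group or a longer alkyl chain on the amide nitrogen, or a methyl ester in place of the amide, would return to the level of compound 1 or stay with compound 4 also remains open.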